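Methoxy for cyano in a thiophenylmethyl phenoxyacetamide series

A few compounds are considered here, and "the series" means these few. Any claim that something is new, unique, unknown or untested is made for them only; others in the source may bear on it.

Measured so far:
compound 1 `CCCc1ccc(OCC(=O)N(CC)Cc2cccs2)cc1` gives 1810 nM in an assay on HEK293 cells for agonist activity at transient receptor potential cation channel subfamily M member 8 (Homo sapiens), read by fluorescence and calcium flux, with a stated time of 15 min; on this read-out lower numbers stand for an effect already at smaller amounts and higher numbers for an effect only at larger amounts of compound;
compound 2 `COc1ccc(OCC(=O)N(Cc2cccs2)c2ccn[nH]2)cc1` gives 3.7 nM;
compound 3 `CCN(Cc1cccs1)C(=O)COc1ccc(C#N)cc1` gives 1990 nM.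

Compound 3 stands at the highest of the three numbers. Its nearest neighbour is compound 1, which shares the same nitrogen substitution; the step of a 1.1-fold higher number from compound 1 to compound 3 (0.04 log units; within the scatter) lies within the scatter, so the exchange of propyl for cyano on the aromatic carbon left the read-out essentially unchanged. Compound 2 sits far lower, but it differs from compound 3 both at the aromatic carbon and at the amide nitrogen, so its value alone cannot tell which change drives the gap.

Compound 4 `CCN(Cc1cccs1)C(=O)COc1ccc(OC)cc1` is not yet measured. It differs from compound 3 by methoxy in place of cyano on an aromatic carbon. For the measured compounds named here, the only measured step at the same position is the one from compound 1 to compound 3, which was within the scatter. Compound 2 carries the same methoxy and gives a very low number, yet its nitrogen substituent is another. On this basis compound 4 is expected to show a step of a 2.0-fold lower number from compound 3 to compound 4 (0.30 log units; within the scatter), a modest lowering, and its estimated value is 1000 nM, with a range from 250 nM to 4000 nM.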

Compound 4, half-maximal effective concentration: 120 nM
Estimate against measurement, compound 4: 8.3-fold (0.92 log units) above; measured number below the stated range.
By their numbers in this assay, from the lowest: compound 2; then compound 4; then compounds 1 and 3 (each within the scatter of the next).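

In this assay the aromatic carbon para to a large group proves sensitive to the group it carries: methoxy gives a 17-fold lower number from compound 3 to compound 4 (1.22 log units; beyond the scatter) and likewise a 15-fold lower number from compound 1 to compound 4 (1.18 log units; beyond the scatter), whereas exchanging propyl for cyano gave only a 1.1-fold higher number from compound 1 to compound 3 (0.04 log units; within the scatter) and so showed no such sensitivity. With methoxy held fixed, the amide-type nitrogen also matters on its own, with a 32-fold higher number from compound 2 to compound 4 (1.51 log units; beyond the scatter), so the low number of compound 2 cannot be credited to methoxy alone. Nothing available explains either step.

The compounds shown leave open whether ethoxy or an amine on the same aromatic carbon would give a number as low as methoxy does. They also leave open whether 1H-pyrazol-5-yl on the amide-type nitrogen would lower the number as far with cyano or propyl on the aromatic carbon.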